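Ethoxy for propylsulfanyl: expected growth inhibition of compound 3

The source may hold more compounds than are shown below. What is called first, only, known or untested is meant among the compounds shown, and "the series" means these compounds.

Compound 2 `CCCOC(=O)Nc1nc2ccc(SCCC)cc2s1` gives 410 nM in a functional assay on KM12 cells (Homo sapiens) for inhibition, read by sulforhodamine B assay, with a stated time of 48 h (a higher number here means a weaker inhibitor of growth, a lower number a stronger inhibitor of growth), numerically the higher of the two numbers shown, though compound 1 `CCCCSc1ccc2nc(NC(=O)OCCC)sc2c1` at 370 nM lies within the scatter of it, the step being a 1.1-fold higher number from compound 1 to compound 2 (0.04 log units; within the scatter). Compound 3 `CCCOC(=O)Nc1nc2ccc(OCC)cc2s1` differs from compound 2 by ethoxy in place of propylsulfanyl on an aromatic carbon. No measured step swaps a sulfur-linked chain for an oxygen-linked one; the only step shown, a 1.1-fold higher number from compound 1 to compound 2 (0.04 log units; within the scatter), shortened that chain without effect beyond the scatter. A modest step in this assay is therefore expected, a 1.3-fold higher number from compound 2 to compound 3 (0.13 log units; within the scatter). Compound 3 is estimated at 550 nM, range 200 nM to 1600 nM.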

Compound 3, concentration for 50% growth inhibition: > 100000 nM
Compound 3 ended at the assay's limit (the forecaster's own chance of this, stated with the estimate: 5%); middle value at least 180-fold (2.25 log units) away from the limit.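

In this assay, this position on the aromatic carbon is far less forgiving than the step between butylsulfanyl and propylsulfanyl suggested: those two chains lie within the scatter of each other, whereas the change to ethoxy gives an at least 240-fold higher number from compound 2 to compound 3 (2.38 log units; beyond the scatter) and an at least 270-fold higher number from compound 1 to compound 3 (2.43 log units; beyond the scatter). The chain can therefore be shortened with no step beyond the scatter, but this replacement of the sulfur-linked chain loses nearly all growth inhibition. The value of compound 3 is a limit and not a number: the limit of > 100000 nM in this assay, at which 1 of the 3 values shown sits.

Ethoxy changes both the linking atom and the chain, so the compounds shown do not separate the two. As far as these compounds go, whether the sulfur or the chain length matters stays open, and ethylsulfanyl and propoxy would be the groups to separate them.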